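Methoxycarbonyl to acetoxymethyl: notes on compound 4

The compounds below may be only part of what the source reports. "The series", "measured", "known", "first", "only" and "open" are said of these compounds alone.

In a functional assay on KB cells (Homo sapiens) for cytotoxicity, read by MTT assay, with a stated time of 72 h (on this read-out higher numbers stand for an effect only at larger amounts of compound and lower numbers for an effect already at smaller amounts), compound 1 `CCc1cccc2c(OC)c(-c3occ(C)c3C(=O)OC)ccc12` gives 1.7 ug/mL. Compound 3 `CCOc1c(-c2occ(C)c2C(=O)OC)ccc2c(CC)cccc12` gives 1.8 ug/mL, and the two stand level, with a 1.1-fold higher number from compound 1 to compound 3 (0.02 log units; within the scatter). Compound 2 `CCCOC(=O)c1c(C)coc1-c1ccc2c(CC)cccc2c1OC` reads > 10 ug/mL, which is a limit of the assay and not a number.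

Compound 4 `CCOc1c(-c2occ(C)c2COC(C)=O)ccc2c(CC)cccc12` has acetoxymethyl in place of methoxycarbonyl on an aromatic carbon of the five-membered aromatic ring with 1 oxygen, and otherwise matches compound 3: acetoxymethyl in place of methoxycarbonyl on an aromatic carbon.

The measured step that bears most directly is the one made on the methoxycarbonyl group itself, where ethyl in place of hydrogen gave an at least 5.8-fold higher number from compound 1 to compound 2 (0.76 log units; beyond the scatter). The change on the oxygen on the aromatic ring, seen in compound 3, bears less, having given a 1.1-fold higher number from compound 1 to compound 3 (0.02 log units; within the scatter). Since compound 2 shows that this group can respond, a modest rise in this assay is expected, not a step as large as that one. The expected step is a 2.2-fold higher number from compound 3 to compound 4 (0.35 log units; beyond the scatter). For compound 4 the estimate is 4 ug/mL, with an expected range of 1.2 ug/mL to 10 ug/mL.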

Compound 4, concentration for half-maximal effect: > 10 ug/mL
Compound 4: only a limit was reported; the forecaster's own chance of this, stated with the estimate: 15%; middle value at least 2.5-fold (0.39 log units) away from the limit.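

In this assay, acetoxymethyl in place of methoxycarbonyl gives an at least 5.5-fold higher number from compound 3 to compound 4 (0.74 log units; beyond the scatter). From the compounds shown here alone, for compound 4 this rests on a limit of the assay and not a number, so the true size of the step stays unknown. Changes to the group at this position now give steps beyond the scatter in both compound 2 and compound 4, which the earlier pair alone could not show, but the two steps cannot be ranked, as both compounds end at the same limit: the limit of > 10 ug/mL in this assay, at which 2 of the 4 values shown sit.

The compounds shown leave open how far past that limit compound 2 and compound 4 lie. They also leave open how a carboxylic acid, a hydroxymethyl group or a primary amide would read at this place on the five-membered aromatic ring.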